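Thiophen-2-yl in place of phenyl: working notes

This account rests on a few compounds, and the source may have more. Where it says the series, first, only, none or still open, it means among the compounds named here.

Measured in a functional assay on DU-145 cells (Homo sapiens) for cytotoxicity, read by ELISA, with a stated time of 2 days; on this read-out lower numbers stand for stronger inhibition and higher numbers for weaker inhibition:
- compound 1 `Oc1cccc(-c2cc(-c3ccccc3)cc(-c3ccco3)n2)c1` gives 14400 nM
- compound 2 `Oc1cccc(-c2cc(-c3ccccc3)nc(-c3ccccc3)c2)c1` gives 17900 nM

These two compounds differ in more than one place, so neither comparison isolates a single structural change. Compound 2, at 17900 nM, lies within the usual scatter of compound 1, at 14400 nM, and the pair cannot be ranked on these numbers.

The next compound is compound 3 `Oc1cccc(-c2cc(-c3ccccc3)nc(-c3cccs3)c2)c1`, which carries thiophen-2-yl in place of phenyl on an aromatic carbon, next to the ring nitrogen (thiophen-2-yl in place of phenyl on an aromatic carbon). Among the compounds with values here, no measured pair shows what such an exchange does in this assay. Within the data shown here, the only guide is the narrow spread of the two known values, with compound 2 at 17900 nM as the starting point. No step beyond the scatter is therefore expected, and no direction can be favoured with confidence. The estimated change, a 1.2-fold lower number from compound 2 to compound 3 (0.08 log units; within the scatter), is expected to remain within the scatter. For compound 3 the expected value is 15000 nM, with an estimated range of 6500 nM to 35000 nM.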

Compound 3, half-maximal inhibitory concentration: 19700 nM
The estimate for compound 3 lay 1.3-fold (0.12 log units) below the measured number, within the range that was stated.
By their numbers in this assay, from the lowest: compounds 1, 2 and 3 (each within the scatter of the next).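

In this assay, thiophen-2-yl in place of phenyl on an aromatic carbon, next to the ring nitrogen, gives a 1.1-fold higher number from compound 2 to compound 3 (0.04 log units; within the scatter) and provides the only single-place comparison among the compounds shown. At this position, the five-membered aromatic ring with its sulfur and the six-membered aromatic ring of carbon only therefore cannot be told apart on this read-out. No measurement on the cause of this result is available.

As far as these compounds go, whether a group of a different kind at this position, such as an amine, a carboxylic acid or a longer alkyl chain, would give a step beyond the scatter remains open. Also open, from the compounds shown here alone, is whether the same exchange gives a similar step elsewhere on the shared core, or when the 3-hydroxyphenyl group is altered, for instance by a methoxy group in place of the hydroxy group.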